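Adding a Sulfur-Bearing Group to Compound 1

The compounds below may be only part of what the source reports. "The series", "measured", "known", "first", "only" and "open" are said of these compounds alone.

- compound 1 `CNC(=O)c1cc(Oc2ccc(C3CC(c4ccc([N+](=O)[O-])cc4)=NN3)cc2)ccn1`: "not determined" (no result reported)
- compound 2 `CNC(=O)c1cc(Oc2ccc(C3CC(c4ccc(Cl)cc4)=NN3)cc2)ccn1`: 20500 nM

Compound 1 has no place on the scale of a functional assay on A549 cells (Homo sapiens) for cytotoxicity, read by MTT assay, with a stated time of 72 h (a lower number here means a stronger inhibitor, a higher number a weaker inhibitor), since compound 1 has only this result ("not determined" (no result reported)). The nearest number comes from compound 2 (20500 nM), which marks a weak inhibitor and gives the only anchor available.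

Compound 3 `CNC(=O)c1cc(Oc2ccc(C3CC(c4ccc([N+](=O)[O-])cc4)=NN3C(N)=S)cc2)ccn1` comes from compound 1 through a single change on an amine nitrogen in a ring: a group of 3 heavy atoms (1 carbon, 1 nitrogen, 1 sulfur; no ring) in place of a hydrogen atom, on an amine nitrogen in a ring. Without a number for compound 1, the size of this step cannot be measured. A modest shift towards stronger inhibition in this assay is expected, meaning a somewhat lower number than the anchor, although this expectation is uncertain.

Compound 3 is estimated at 12000 nM, with an expected range from 3000 nM to 45000 nM.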

Compound 3, half-maximal inhibitory concentration: > 50000 nM
Compound 3: no number, only a limit; the forecaster's own chance of this, stated with the estimate: 15%; middle value at least 4.1-fold (0.61 log units) away from the limit.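

The step from compound 1 to compound 3 cannot be read, as compound 1 has no number. Compound 3 gives > 50000 nM, which is a limit and not a number. As far as these compounds go, whether the added group on the amine nitrogen changes inhibition in this assay stays open.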